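The source may report more compounds than this note shows. Statements on the series, on what has been measured and on what is new or still open speak of the compounds shown alone.

Measured in a functional assay on MDA-MB-435 cells (Homo sapiens) for cytotoxicity, read by MTT assay, with a stated time of 72 h; on this read-out lower numbers stand for stronger inhibition and higher numbers for weaker inhibition:
- compound 1 `COc1ccc(CNC(=O)c2nc(Br)c3cccnc3c2N[C@H]2CC[C@H](N)CC2)cc1`: 5000 nM
- compound 2 `N[C@H]1CC[C@H](Nc2c(C(=O)NCc3ccccn3)nc(Br)c3cccnc23)CC1`: 4000 nM

Compound 2 gives 4000 nM, which is level, within the scatter, with compound 1 at 5000 nM. Only these two numbers are available, so neither compound can be ranked above the other.

Compound 3 `N[C@H]1CC[C@H](Nc2c(C(=O)NCc3cccc(C(F)(F)F)c3)nc(Br)c3cccnc23)CC1` differs from compound 2 in one place: 3-(trifluoromethyl)phenyl in place of pyridin-2-yl on a saturated chain carbon bound to an amide-type nitrogen. In words, 3-(trifluoromethyl)phenyl stands in place of pyridin-2-yl on a saturated chain carbon bound to an amide-type nitrogen.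

Going by the values given here, one measured step bears on this change, at the same place: a 1.3-fold lower number from compound 1 to compound 2 (0.10 log units; within the scatter), which put pyridin-2-yl in place of 4-methoxyphenyl. That single exchange of aromatic rings moved the number very little, so no clear shift in either direction is expected in this assay. Among the compounds with values here, no measured compound carries a trifluoromethyl group, which keeps the range wide.

The expected change is a 1.1-fold lower number from compound 2 to compound 3 (0.06 log units; within the scatter). For compound 3 the estimated value is 3500 nM, with an expected range of 1500 nM to 8000 nM.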

Compound 3, half-maximal inhibitory concentration: 4200 nM
Estimate against measurement, compound 3: 1.2-fold (0.08 log units) below; the range from low to high includes it.
By their numbers in this assay, from the lowest: compounds 2, 3 and 1 (each within the scatter of the next).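

In this assay, putting 3-(trifluoromethyl)phenyl in place of pyridin-2-yl gives a 1.1-fold higher number from compound 2 to compound 3 (0.02 log units; within the scatter), and putting it in place of 4-methoxyphenyl gives a 1.2-fold lower number from compound 1 to compound 3 (0.08 log units; within the scatter). This place, on a saturated chain carbon bound to an amide-type nitrogen, now carries three different aromatic rings, one holding a ring nitrogen and two of carbon only, and all three compounds stand level, where the earlier pair offered just one exchange. Nothing measured here explains why these rings read alike.

From the compounds shown here alone, all three groups are aromatic rings, so it stays open whether a group without a ring, such as an amine or a carboxylic acid, or a longer chain carrying the ring, would read differently. Going by these compounds, it also stays open whether a group other than the bromine on the shared core would change the number.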